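The compounds below may be only part of what the source reports. "The series", "measured", "known", "first", "only" and "open" are said of these compounds alone.

Measured compounds:
compound 1 `CN(C)/N=N/c1n[nH]cc1C(N)=O` — 3.49
compound 2 `C=CCN(C)/N=N/c1n[nH]cc1C(N)=O` — 3.77
compound 3 `CN(CCO)/N=N/c1n[nH]cc1C(N)=O` — 3.1

Among these three, compound 3 stands lowest in a functional assay on L1210 cells (Mus musculus) for antiproliferative activity; on this read-out lower numbers stand for lower potency and higher numbers for higher potency (the scale is a negative logarithm): a number 0.39 log units lower from compound 1 to compound 3 (beyond the scatter) and a number 0.67 log units lower from compound 2 to compound 3 (beyond the scatter), while compound 1 and compound 2 lie within the scatter of each other, a number 0.28 log units higher from compound 1 to compound 2 (within the scatter). Compound 4 `CCCCN(C)/N=N/c1n[nH]cc1C(N)=O` differs from compound 3 by ethyl in place of hydroxy on a saturated chain carbon, two bonds along the chain from an amine nitrogen. The two steps that bear on this are the ones in which hydroxymethyl entered, and each lowered the number by a modest amount. Taking the hydroxy out and lengthening the chain to butyl is therefore expected to reverse that loss, back to about the level of compound 2. The expected step is a number 0.70 log units higher from compound 3 to compound 4 (beyond the scatter), upward. Compound 4 is estimated at 3.8, between 3.4 and 4.2.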

Compound 4, logarithm of the reciprocal of the active concentration, log(1/C): 3.81
Compound 4: the middle estimate sits 0.01 log units below what was measured, and the stated range covers the measured number.
By their numbers in this assay, from the lowest: compound 3; then compounds 1, 2 and 4 (each within the scatter of the next, the first and the last beyond it).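

At this position a longer saturated chain is tolerated in this assay: ethyl in place of hydroxy (a number 0.71 log units higher from compound 3 to compound 4 (beyond the scatter)) shows that the drop seen with the hydroxy-bearing chain does not carry over to a chain without hydroxy. Propyl in place of vinyl (a number 0.04 log units higher from compound 2 to compound 4 (within the scatter)) shows that the vinyl is not required at this level. Propyl in place of hydrogen (a number 0.32 log units higher from compound 1 to compound 4 (beyond the scatter)) is the first upward step of this kind beyond the scatter.

Nothing at hand accounts for these steps. From the compounds shown here alone, a longer chain such as hexyl, a branched chain such as isobutyl, or a chain carrying an amine remains open.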